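Trifluoromethoxy Added to the Anilino Ring of Compound 1

The source may hold more compounds than are shown below. What is called first, only, known or untested is meant among the compounds shown, and "the series" means these compounds.

Measured compounds:
compound 1 `Nc1ccccc1NC(=O)c1ccc(Cn2cnc3c(Nc4ccccc4)nc(Cl)nc32)cc1`: 77.8%
compound 2 `CCCCn1cnc2c(Nc3ccccc3)nc(NCOCc3ccc(/C=C/C(=O)Nc4ccccc4N)cc3)nc21`: 34.2%

In a functional assay on NCI-H460 cells (Homo sapiens) for antiproliferative activity, read by CCK-8 assay, with a stated time of 72 h, tested at 8 uM (on this read-out higher numbers stand for a stronger effect at the one concentration tested and lower numbers for a weaker effect), compound 1 gives 77.8%, the higher of the two numbers. Compound 2 gives 34.2%, a gap beyond the scatter. Compound 3 `Nc1ccccc1NC(=O)c1ccc(Cn2cnc3c(Nc4cccc(OC(F)(F)F)c4)nc(Cl)nc32)cc1` has not yet been measured. It differs from compound 1 by one change: trifluoromethoxy in place of hydrogen on an aromatic carbon. Among the measured compounds shown here, no measured pair shows this change, so nothing here tells how large its effect is. The expected step of a number 7.8 percentage points lower from compound 1 to compound 3 (within the scatter) is small, at most a modest fall, likely within the scatter. Compound 3 is therefore estimated at 70%, with a range from 50% to 88%.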

Compound 3, a percentage reported as inhibition, at one concentration (the size of the read-out at that concentration, not a potency): 62.4%
The estimate for compound 3 lay 7.6 percentage points above the measured number, within the range that was stated.
By their numbers in this assay, from the lowest: compound 2; then compound 3; then compound 1.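

In this assay, placing trifluoromethoxy on the anilino ring gives a number 15.4 percentage points lower from compound 1 to compound 3 (beyond the scatter). This puts a first size on this change: the position takes the group at a modest cost, and compound 3 still shows a clear effect at the one concentration tested. No available measurement says why the number falls. Still open, on these data alone, is how other groups at this same place would compare, such as a single fluorine, a methyl, an amine or a carboxylic acid. Also open, as far as these compounds go, is how trifluoromethoxy would behave elsewhere on this ring.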